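The source may hold more compounds than are shown below. What is called first, only, known or untested is meant among the compounds shown, and "the series" means these compounds.

The series shares one core: compound 1 is `CCCCCOC(=O)N1CCN(C(=O)[C@H](CCC(=O)O)NC(=O)c2cc(N3CCC(OCCO)CC3)nc(-c3ccccc3)n2)CC1` and compound 2 is `CCCCCOC(=O)N1CCN(C(=O)[C@H](CCC(=O)O)NC(=O)c2cc(N3CCC(COC)CC3)nc(-c3ccccc3)n2)CC1`. In an ADME assay on microsomes from liver (Homo sapiens) for metabolic stability (a lower number here means that less of the compound is left, a higher number that more of the compound is left), compound 1 gives > 80%, which is a limit of the assay and not a number. In this assay compound 2 gives > 80%, likewise a limit rather than a number. The step that the two limits leave unreadable from compound 1 to compound 2 therefore cannot be read, because of the limit of > 80% in this assay, at which 2 of the 2 values shown sit. On the numbers shown, compound 2 stands at that limit, and the one further value shown is also a limit.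

Compound 3 is `CCCCCOC(=O)N1CCN(C(=O)[C@H](CCC(=O)O)NC(=O)c2cc(N3CCC(C(=O)N4CCCC4)CC3)nc(-c3ccccc3)n2)CC1`. It differs from compound 2 in one place: (pyrrolidin-1-yl)carbonyl in place of methoxymethyl on a saturated ring carbon. Going by the values given here, the only measured step, from compound 1 to compound 2, concerns a change on a saturated ring carbon as well, but its size is not readable, so no step size can be taken from it. The expectation for compound 3 in this assay therefore rests on the two limits alone: a step staying near them is expected, a step that the limit leaves unreadable from compound 2 to compound 3, with no direction beyond the scatter. Compound 3 is estimated at 85%, between 68% and 96%.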

Compound 3, percent of the compound remaining: > 80%
Compound 3: no number, only a limit; the forecaster's own chance of this, stated with the estimate: 65%; the middle value lies beyond the limit too.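

In this assay compound 3 gives > 80% as a limit of the assay and not a number. No new step can be read from compound 1 or compound 2 to compound 3, because of this: (the limit of > 80% in this assay, at which 3 of the 3 values shown sit). The compounds shown leave open whether compound 1, compound 2 and compound 3 differ at all in the percent remaining.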